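This account rests on a few compounds, and the source may have more. Where it says the series, first, only, none or still open, it means among the compounds named here.

Measured so far:
- Compound 1, `CC(=O)NCc1cccc(Cn2nc(NS(=O)(=O)c3ccc(Cl)s3)c3ccccc32)c1`: 3.3
- Compound 2, `COc1cccc2c1c(NS(=O)(=O)c1ccc(Cl)s1)nn2Cc1cccc(CNC(=O)C2COC2)c1`: 4

Both compounds were measured in a physicochemical assay for lipophilicity; on this read-out lower numbers stand for lower lipophilicity and higher numbers for higher lipophilicity. Compound 2 stands highest of the two numbers; its nearest neighbour, compound 1, sits lower by a gap that lies beyond the usual scatter of this assay. The two structures differ in several places at once, so no single cause of that gap can be read from the data.

Compound 3, `COc1cccc2c1c(NS(=O)(=O)c1ccc(Cl)s1)nn2Cc1cccc(CNC(=O)[C@@H]2CCCCN2)c1`, has not yet been measured in this assay. It differs from compound 2 in exactly one place: piperidin-2-yl in place of oxetan-3-yl on a carbonyl carbon. Going by the values given here, no step between measured compounds shows this exchange, so any expectation rests on the structural change alone. The exchange is expected to move the value of compound 3 downward from compound 2 by a modest step, a number 0.80 log units lower from compound 2 to compound 3 (beyond the scatter), with the direction less certain than the size. Compound 3 is therefore estimated at 3.2, within a range from 2.4 to 3.9.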

Compound 3, distribution coefficient: 3.3
Compound 3: the middle estimate sits 0.10 log units below what was measured; the measured number falls inside the stated range.
By their numbers in this assay, from the lowest: compounds 1 and 3 (each within the scatter of the next); then compound 2.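

In this assay, going by these compounds alone, putting piperidin-2-yl in place of oxetan-3-yl on a carbonyl carbon gives a number 0.70 log units lower from compound 2 to compound 3 (beyond the scatter) and is the first step here to change one place only. It shows that the number responds to the group held at this position. The entering ring is six-membered rather than four-membered, has nitrogen instead of oxygen as its hetero atom and brings a hydrogen-bond donor, and no measurement here explains the step or separates these changes.

Still open, from the compounds shown here alone, is whether a cyclohexyl ring, made of carbon alone, or an open-chain amine on the same carbonyl carbon would give a similar number, which would help separate the part played by the ring from that of its nitrogen. The mirror-image form of the piperidin-2-yl group also remains an open comparison.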